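Replacing 3-aminophenyl with 1H-indol-6-yl in compound 3

This account rests on a few compounds, and the source may have more. Where it says the series, first, only, none or still open, it means among the compounds named here.

In a functional assay on A549 cells (Homo sapiens) for antiproliferative activity, read by MTT assay, with a stated time of 48 h (a lower number here means a stronger inhibitor, a higher number a weaker inhibitor), compound 1 `COc1ccc(-c2nc3cccc(-c4cc(OC)c(OC)c(OC)c4)c3o2)cc1F` gives 1800 nM and compound 3 `COc1cc(-c2cccc3nc(-c4cccc(N)c4)oc23)cc(OC)c1OC` gives 4700 nM, the higher of the two actual numbers. That gap is a 2.6-fold higher number from compound 1 to compound 3 (0.42 log units; beyond the scatter). For compound 2 `COc1cc(-c2cccc3nc(-c4cccc(Cl)c4)oc23)cc(OC)c1OC` the assay reports only a limit, > 25000 nM. Compound 4 `COc1cc(-c2cccc3nc(-c4ccc5cc[nH]c5c4)oc23)cc(OC)c1OC` has 1H-indol-6-yl in place of 3-aminophenyl on an aromatic carbon. Among the measured compounds shown here, no measured step makes this exact exchange. The nearest exchanges, at the same carbon, range from a 2.6-fold higher number from compound 1 to compound 3 (0.42 log units; beyond the scatter) to an at least 13-fold higher number from compound 1 to compound 2 (1.14 log units; beyond the scatter), while an at least 5.3-fold lower number from compound 2 to compound 3 (0.72 log units; beyond the scatter). Those steps point in both directions, so no step beyond the scatter is expected in this assay, though with wide uncertainty. The expected change is a 1.0-fold lower number from compound 3 to compound 4 (0.02 log units; within the scatter). Compound 4 is estimated at 4500 nM, within a range of 1200 nM to 20000 nM.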

Compound 4, half-maximal inhibitory concentration: 55 nM
Compound 4: middle estimate off by 82-fold (1.91 log units), on the high side; measured number outside the range, below it.
By their numbers in this assay, from the lowest: compound 4; then compound 1; then compound 3. At a limit, above all of these: compound 2.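

In this assay, the aromatic carbon next to the ring nitrogen and next to the ring oxygen accepts a two-ring group, and 1H-indol-6-yl gives far lower numbers than any single-ring aryl group shown: an 85-fold lower number from compound 3 to compound 4 (1.93 log units; beyond the scatter), and a 33-fold lower number from compound 1 to compound 4 (1.51 log units; beyond the scatter). Against the 3-chlorophenyl group, the change gives an at least 450-fold lower number from compound 2 to compound 4 (2.65 log units; beyond the scatter). That step rests on a limit for compound 2: the limit of > 25000 nM in this assay, at which 1 of the 4 values shown sits.

The compounds shown leave open whether the gain depends on the indole's ring hydrogen on nitrogen. A benzofuran, or an indole carrying a methyl group on that nitrogen, would address this.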